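The source may hold more compounds than are shown below. What is called first, only, known or untested is meant among the compounds shown, and "the series" means these compounds.

Compound 2, `CCN1CCN(c2cc(C)c3cc(NC(=O)c4ccccc4C)ccc3n2)CC1`, is the compound from which this account sets out. In a functional assay on SK-BR-3 cells (Homo sapiens) for antiproliferative activity, read by MTT assay, with a stated time of 72 h (on this read-out lower numbers stand for stronger inhibition and higher numbers for weaker inhibition), compound 2 gives 29200 nM, the higher of the two numbers obtained here. Compound 1, `Cc1cc(NCCN(C)C)nc2ccc(NC(=O)c3ccc(Cl)c(Cl)c3)cc12`, gives 6670 nM in this assay, a lower number than that of compound 2, though no single-place change connects the two. Compound 3, `Cc1cc(N(C)C)nc2ccc(NC(=O)c3ccc(Cl)c(Cl)c3)cc12`, reaches only the limit of this assay, > 50000 nM. Among the measured compounds shown here, the one measured single-place step is an at least 7.4-fold higher number from compound 1 to compound 3 (0.87 log units; beyond the scatter), and it concerns the amine side of the shared core, not the amide side.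

Compound 4, `CCN1CCN(c2cc(C)c3cc(NC(=O)c4cccc(F)c4)ccc3n2)CC1`, differs from compound 2 at the other end: 3-fluorophenyl in place of 2-methylphenyl on a carbonyl carbon. For the measured compounds named here, no measured step touches the aryl group on the carbonyl carbon, so nothing here tells how far such a change can move this assay; the limit of > 50000 nM in this assay, at which 1 of the 3 values shown sits, only marks where one value sits. He therefore expects compound 4 to stay in the general region of compound 2, with a slight gain plausible, the estimated step being a 1.9-fold lower number from compound 2 to compound 4 (0.29 log units; within the scatter). His estimate for compound 4 is 15000 nM, within 4000 nM to 50000 nM.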

Compound 4, half-maximal inhibitory concentration: 24900 nM
Compound 4: the middle estimate sits 1.7-fold (0.22 log units) below what was measured; the measured number falls inside the stated range.
By their numbers in this assay, from the lowest: compound 1; then compounds 4 and 2 (each within the scatter of the next). At a limit, above all of these: compound 3.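

In this assay, among the compounds shown here, the first measured change to the aryl group on the carbonyl carbon is a 1.2-fold lower number from compound 2 to compound 4 (0.07 log units; within the scatter), so 2-methylphenyl and 3-fluorophenyl cannot be told apart at this position. For the compounds shown here, the only earlier step lay on the amine side of the shared core and went beyond the scatter, whereas this pair, with the amine side held fixed, shows a swap of one aryl group for another that produces no readable difference. The values shown give no account of this outcome.

On these data alone, whether any group on this carbonyl carbon can move the number remains open: this amine side carries only these two aryl groups, and the aryl group of compound 1 and compound 3 comes with a different amine side. Also open, as far as these compounds go, is how a phenyl ring bearing an amine or a carboxylic acid would read here.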